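The compounds below may be only part of what the source reports. "The series", "measured", "known", "first", "only" and "open" are said of these compounds alone.

Compound 1, `COc1cc2c(cc1OC)CN(CCCC(=O)c1c(C)c(OC)c(OC)c(OC)c1OC)CC2`, is reported in an assay on membranes from brain for displacement of a labelled ligand from Sigma non-opioid intracellular receptor 1 (Cavia porcellus), read by scintillation counting, with a stated time of 120 min (a lower number here means a stronger inhibitor, a higher number a weaker inhibitor), only as a limit, > 1000 nM. Compound 2, `COc1cc2c(c(OC)c1OC)CCN(CCCC(=O)c1c(C)c(OC)c(OC)c(OC)c1OC)C2`, likewise gives only a limit in this assay, > 1000 nM. Compound 3, `COc1cc2c(cc1OC)CN(CCCCC(=O)c1c(C)c(OC)c(OC)c(OC)c1OC)CC2`, gives 160 nM in this assay.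

Compound 4, `COc1cc2c(c(OC)c1OC)CCN(CCCCC(=O)c1c(C)c(OC)c(OC)c(OC)c1OC)C2`, has not been measured. The difference between the core of compound 1 and the core of compound 3 is not broken down here. Compound 2 differs from compound 1 by methoxy in place of hydrogen on an aromatic carbon, and the step that the two limits leave unreadable from compound 1 to compound 2 cannot be read because of the limit of > 1000 nM in this assay, at which 2 of the 3 values shown sit. Compound 4 differs from compound 3 by methoxy in place of hydrogen on an aromatic carbon, the same change. Compound 4 is expected to give about 200 nM, between 60 nM and 700 nM. The expected step of a 1.3-fold higher number from compound 3 to compound 4 (0.10 log units; within the scatter) rests on compound 3 at 160 nM, since the earlier step gives no readable size.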

Compound 4, inhibition constant: > 1000 nM
Compound 4: a limit, no number (the forecaster's own chance of this, stated with the estimate: 20%); middle value at least 5.0-fold (0.69 log units) from the limit.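

In this assay, methoxy in place of hydrogen on an aromatic carbon gives an at least 6.2-fold higher number from compound 3 to compound 4 (0.79 log units; beyond the scatter), so on this core the change costs binding rather than leaving it unchanged. On these data alone, the value of compound 4 is only a limit, and the full size of this step remains unknown. Whether the change acts in the same way on the core of compound 1 cannot be said, because the step on that core cannot be read: the limit of > 1000 nM in this assay, at which 3 of the 4 values shown sit.

The compounds shown leave open whether a longer chain than that of compound 3 would strengthen binding further. They also leave open whether ethoxy or fluorine, set in place of the entering methoxy, would give a readable number.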